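Chloro in place of methoxy, starting from a limit

This account rests on a few compounds, and the source may have more. Where it says the series, first, only, none or still open, it means among the compounds named here.

Measured in an ADME assay on HEK293 cells (Homo sapiens) for cytotoxicity, read by luminescence, with a stated time of 72 h; a lower number here means that less compound is needed, a higher number that more compound is needed for the effect:
- Compound 1 `CCOC(=O)c1c(-c2cccc(-c3ccccc3)c2)[nH]c2cc(OC)ccc2c1=O`: > 22000 nM, a limit
- Compound 2 `CCOC(=O)c1c(-c2cccc(OCC(C)C)c2)[nH]c2cc(OC)ccc2c1=O`: > 22000 nM, a limit
- Compound 3 `CCOC(=O)c1c(-c2cccc(F)c2)[nH]c2cc(OC)ccc2c1=O`: > 22000 nM, a limit

Compound 1 offers no exact number as a starting point, only the limit > 22000 nM. The whole set looks the same, with the limit of > 22000 nM in this assay, at which 3 of the 3 values shown sit.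

Compound 4 `CCOC(=O)c1c(-c2cccc(-c3ccccc3)c2)[nH]c2cc(Cl)ccc2c1=O` keeps the core of compound 1 and alters one group: chloro in place of methoxy on an aromatic carbon. In words, this is chloro in place of methoxy on an aromatic carbon.

Among the compounds with values here, no measured step touches the methoxy group. The steps available exchange a different group, and none has a readable size: a step that the two limits leave unreadable from compound 1 to compound 2, a step that the two limits leave unreadable from compound 1 to compound 3 and a step that the two limits leave unreadable from compound 2 to compound 3. The data therefore give no direction for this change.

The expectation rests on compound 1 and its limit > 22000 nM, so no step beyond the scatter is expected. The expected result is a step that the limit leaves unreadable from compound 1 to compound 4. Compound 4 will most likely be reported as a limit too. For compound 4 the estimated value is 25000 nM, with an expected range from 12000 nM to 50000 nM.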

Compound 4, half-maximal effective concentration: > 22000 nM
Compound 4 gave a limit, no number; the forecaster's own chance of this, stated with the estimate: 85%; the middle value is on the limit's open side.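

Compound 4 gives > 22000 nM, which is a limit and not a number, so chloro in place of methoxy yields no readable step from compound 1 to compound 4. The compounds shown leave open what concentration of any of them would give a half-maximal effect in this assay, and all share one reading: the limit of > 22000 nM in this assay, at which 4 of the 4 values shown sit.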